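This account rests on a few compounds, and the source may have more. Where it says the series, first, only, none or still open, it means among the compounds named here.

In an ADME assay on L6 cells (Rattus norvegicus) for cytotoxicity, read by fluorescence and resazurin assay, with a stated time of 72 h (on this read-out lower numbers stand for an effect already at smaller amounts and higher numbers for an effect only at larger amounts of compound), compound 1 `O=c1nc(-c2ccccc2)c2cc(-c3ccccc3)ccc2[nH]1` gives > 50000 nM as a limit and not a number. Compound 2 `CNC(=O)c1cccc(-c2ccc3[nH]c(=O)nc(-c4ccccc4)c3c2)c1` gives > 50000 nM as a limit too. Among the measured compounds shown here, the evidence is the limit of > 50000 nM in this assay, at which 2 of the 2 values shown sit, and the only measured step (a step that the two limits leave unreadable from compound 1 to compound 2) therefore has no readable size. For the measured compounds named here, compound 3 `O=c1nc(-c2ccccc2)c2cc(-c3cncnc3)ccc2[nH]1` carries pyrimidin-5-yl in place of phenyl on an aromatic carbon and no measured step covers that change. No step beyond the scatter and no direction is expected in this assay (an at least 1.1-fold lower number from compound 1 to compound 3 (0.04 log units; that floor lies within the scatter) as the expected step). Compound 3 is estimated at 45000 nM with an expected range of 20000 nM to 60000 nM and a limit rather than a number is expected for it.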

Compound 3, half-maximal effective concentration: > 50000 nM
Compound 3: no number, only a limit; the forecaster's own chance of this, stated with the estimate: 70%; middle value at least 1.1-fold (0.04 log units) away from the limit.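

Among the compounds shown here, compound 1 and compound 3 both give limits, and no step between them can be read. The compounds shown leave open whether either change shifts the read-out at all, and by how much.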